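Trifluoromethyl for fluoro on a hydroxylated core

The source may hold more compounds than are shown below. What is called first, only, known or untested is meant among the compounds shown, and "the series" means these compounds.

The study looks at cytotoxicity in an ADME assay on THP-1 cells (Homo sapiens) for cytotoxicity, read by flow cytometry and propidium iodide staining, with a stated time of 72 h (a lower number here means a stronger inhibitor, a higher number a weaker inhibitor), for a small set of related compounds. Compound 1 `Nc1ccc2oc(-c3ccc(F)cc3)cc(=O)c2c1` gives 10000 nM in this assay. Compound 2 `Nc1ccc2oc(-c3ccc(C(F)(F)F)cc3)cc(=O)c2c1` differs from it by trifluoromethyl in place of fluoro on an aromatic carbon, and in this assay compound 2 gives 1900 nM, so that a 5.3-fold lower number from compound 1 to compound 2 (0.72 log units; beyond the scatter). Compound 3 `Nc1ccc2oc(-c3ccc(F)cc3)c(O)c(=O)c2c1` carries a different core, differing from compound 1 by hydroxy in place of hydrogen on an aromatic carbon; in this assay compound 3 gives 4000 nM, and a 2.5-fold lower number from compound 1 to compound 3 (0.40 log units; beyond the scatter).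

Compound 4 `Nc1ccc2oc(-c3ccc(C(F)(F)F)cc3)c(O)c(=O)c2c1` has not yet been measured in this assay. It differs from compound 3 by trifluoromethyl in place of fluoro on an aromatic carbon. This is the same change already seen from compound 1 to compound 2, where the place of the change reads word for word alike, and that earlier step was a 5.3-fold lower number from compound 1 to compound 2 (0.72 log units; beyond the scatter). The only difference between the two settings is the core, which is hydroxy in place of hydrogen on an aromatic carbon.

With a single precedent for the change, the account rests on that one step. The writer expects the step from compound 3 to compound 4 to be about a 5.0-fold lower number from compound 3 to compound 4 (0.70 log units; beyond the scatter), because the same change gave a 5.3-fold lower number from compound 1 to compound 2 (0.72 log units; beyond the scatter) in this assay. The estimate for compound 4 in this assay is therefore 800 nM, expected to lie between 300 nM and 2500 nM; whether the new core shifts the step is not known from these three measurements.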

Compound 4, half-maximal inhibitory concentration: > 125000 nM
Compound 4 ended at the assay's limit; the forecaster's own chance of this, stated with the estimate: 5%; at least 150-fold (2.19 log units) between middle value and limit.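

In this assay compound 4 gives > 125000 nM, which is a limit of the assay and not a number. Trifluoromethyl in place of fluoro does not carry over from the core of compound 1 to the core of compound 3, since on the second core the change gives an at least 31-fold higher number from compound 3 to compound 4 (1.49 log units; beyond the scatter) and so runs the opposite way to the earlier step: the same change on two cores in this assay, a 5.3-fold lower number (0.72 log units; beyond the scatter) from compound 1 to compound 2 and an at least 31-fold higher number (1.49 log units; beyond the scatter) from compound 3 to compound 4, at least 160-fold (2.21 log units) apart, beyond the scatter of two such steps. Hydroxy in place of hydrogen likewise gives an at least 65-fold higher number from compound 2 to compound 4 (1.81 log units; beyond the scatter), which shows that in these four compounds the two changes do not simply add, but a single pair on each core does not show what lies behind this: the same change on two cores in this assay, a 2.5-fold lower number (0.40 log units; beyond the scatter) from compound 1 to compound 3 and an at least 65-fold higher number (1.81 log units; beyond the scatter) from compound 2 to compound 4, at least 160-fold (2.21 log units) apart, beyond the scatter of two such steps.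

The compounds shown leave open whether this reversal belongs to trifluoromethyl alone or would also appear with a chloro or nitrile group in the same place on the core of compound 3. They also leave open whether a methoxy group in place of the hydroxy would give the same result with trifluoromethyl on the aromatic ring.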